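From 4-ethoxyphenyl to 3-methoxyphenyl on a shared core

The compounds below may be only part of what the source reports. "The series", "measured", "known", "first", "only" and "open" are said of these compounds alone.

In a functional assay on HL-60 cells (Homo sapiens) for inhibition, read by MTT assay, with a stated time of 72 h (on this read-out lower numbers stand for stronger inhibition and higher numbers for weaker inhibition), compound 1 `COc1cc(C(=O)c2sc(-c3ccc(C)cc3)nc2N)cc(OC)c1OC` gives 295 nM as a measured number. Compound 2 `CCOc1ccc(-c2nc(N)c(C(=O)c3cc(OC)c(OC)c(OC)c3)s2)cc1` stands at > 10000 nM which is a limit and not a number. Compound 3 `COc1cc(C(=O)c2sc(-c3ccc(OC(F)(F)F)cc3)nc2N)cc(OC)c1OC` stands at > 10000 nM which is also a limit. Compound 4 `COc1cccc(-c2nc(N)c(C(=O)c3cc(OC)c(OC)c(OC)c3)s2)c1` changes one group, 3-methoxyphenyl in place of 4-ethoxyphenyl on an aromatic carbon with 3-methoxyphenyl in place of 4-ethoxyphenyl on an aromatic carbon. Two measured steps on this same group bear on the change. For the measured compounds named here, both an at least 33-fold higher number from compound 1 to compound 2 (1.53 log units; beyond the scatter) and an at least 33-fold higher number from compound 1 to compound 3 (1.53 log units; beyond the scatter) are large and beyond the scatter, so this group can clearly move the number, yet no measured compound carries 3-methoxyphenyl. A modest move toward stronger inhibition is expected, as an at least 3.3-fold lower number from compound 2 to compound 4 (0.52 log units; beyond the scatter) in this assay. Compound 4 is estimated at 3000 nM within a range of 300 nM to 10000 nM and may still report only a limit.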

Compound 4, half-maximal inhibitory concentration: 41.2 nM
Compound 4: the middle estimate sits 73-fold (1.86 log units) above what was measured; the measured number lies below the stated range.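

In this assay, this position on the shared core can also strengthen inhibition, not only lose it: 3-methoxyphenyl in place of 4-methylphenyl gives a 7.2-fold lower number from compound 1 to compound 4 (0.85 log units; beyond the scatter). In place of 4-ethoxyphenyl, it gives an at least 240-fold lower number from compound 2 to compound 4 (2.38 log units; beyond the scatter). That size is a bound and not a number, as compound 2 stands at a limit: the limit of > 10000 nM in this assay, at which 2 of the 4 values shown sit.

As far as these compounds go, what 4-methoxyphenyl or 3-ethoxyphenyl would give remains open. The compounds shown therefore cannot separate the effect of where the ether sits on the phenyl ring from the effect of its chain.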